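The source may report more compounds than this note shows. Statements on the series, on what has been measured and on what is new or still open speak of the compounds shown alone.

Of the compounds shown here, three sharing one core have been measured in a functional assay on SW-620 cells (Homo sapiens) for cytotoxicity, read by MTT assay, with a stated time of 72 h; a lower number here means a stronger inhibitor, a higher number a weaker inhibitor. Compound 1 (`COc1ccc(/C=C2\CCC/C(=C\c3cccc(Cl)c3)C2=O)cc1OC`) gives 5100 nM, compound 2 (`COc1ccc(/C=C2\CCC/C(=C\c3ccc(OC)c(OC)c3)C2=O)cc1`) gives 6600 nM, and compound 3 (`COc1ccc(/C=C2\CCC/C(=C\c3ccc(Cl)c(Cl)c3)C2=O)cc1OC`) gives 4000 nM. Nothing sets this last value apart: a 1.3-fold lower number from compound 1 to compound 3 (0.11 log units; within the scatter) and a 1.7-fold lower number from compound 2 to compound 3 (0.22 log units; within the scatter) both lie within the scatter, as does a 1.3-fold higher number from compound 1 to compound 2 (0.11 log units; within the scatter).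

Compound 4 (`COc1ccc(/C=C2\CCC/C(=C\c3ccc(O)c(O)c3)C2=O)cc1OC`) carries 3,4-dihydroxyphenyl in place of 3,4-dichlorophenyl on a double-bonded chain carbon bound to a double-bonded ring carbon. Among the measured compounds shown here, all three measured steps changed a group at this same place, and the closest precedent is compound 3 itself, reached with a 1.7-fold lower number from compound 2 to compound 3 (0.22 log units; within the scatter), which brought in the group that now leaves. For the measured compounds named here, none of the measured compounds carries a hydroxyl group, so the entering group is untested and the range must stay wide. With every earlier exchange within the scatter, no step beyond the scatter is expected in this assay. The estimated change is a 1.1-fold lower number from compound 3 to compound 4 (0.06 log units; within the scatter). For compound 4 the expected value is 3500 nM, with an estimated range of 1200 nM to 9000 nM.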

Compound 4, half-maximal inhibitory concentration: 10500 nM
The estimate for compound 4 lay 3.0-fold (0.48 log units) below the measured number; measured number above the stated range.
By their numbers in this assay, from the lowest: compounds 3, 1, 2 and 4 (each within the scatter of the next, the first and the last beyond it).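

At this position, on a double-bonded chain carbon bound to a double-bonded ring carbon, an exchange now moves the number beyond the scatter in this assay: 3,4-dihydroxyphenyl gives a 2.6-fold higher number from compound 3 to compound 4 (0.42 log units; beyond the scatter) and a 2.1-fold higher number from compound 1 to compound 4 (0.31 log units; beyond the scatter), both modest. The position is therefore not indifferent to the group it carries, yet the same entering group gives a 1.6-fold higher number from compound 2 to compound 4 (0.20 log units; within the scatter), so compound 4 cannot be separated from compound 2, and only the chlorinated compounds stand apart from it. Nothing available accounts for this shift.

On these data alone, whether a phenyl group with a single hydroxyl would read like compound 4 or like compound 3 remains open. So does how an amine or a carboxylic acid at this place would read in this assay.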